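This account rests on a few compounds, and the source may have more. Where it says the series, first, only, none or still open, it means among the compounds named here.

Measured so far in an assay on HEK293 cells for displacement of a labelled ligand from Neuronal acetylcholine receptor; alpha3/beta4 (Homo sapiens); a higher number here means a weaker inhibitor, a lower number a stronger inhibitor:
compound 1 `COc1ccc(Nc2cncc(N3CC4CC(C3)N4)c2)cc1` — 2.2 nM
compound 2 `O=[N+]([O-])c1ccc(Nc2ccc(N3CC4CC(C3)N4)cn2)cc1` — 25 nM
compound 3 `O=[N+]([O-])c1ccc(Nc2cncc(N3CC4CC(C3)N4)c2)cc1` — 0.684 nM

In this assay compound 1 gives 2.2 nM, the second highest of the three numbers. Going by the values given here, compound 3 sits nearest with 0.684 nM, and the step of a 3.2-fold lower number from compound 1 to compound 3 (0.51 log units; beyond the scatter) is the one measured change at this position of the shared core. Compound 2, built on a differently arranged core, gives 25 nM and stands furthest from compound 1.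

Compound 4 `c1ccc(Nc2cncc(N3CC4CC(C3)N4)c2)cc1` is the unmeasured member: hydrogen in place of methoxy on an aromatic carbon. Among the compounds with values here, no measured pair shows a methoxy replaced by hydrogen, so the only bearing comes from compound 3 through a 3.2-fold lower number from compound 1 to compound 3 (0.51 log units; beyond the scatter), which shows that the group on that aromatic carbon can move the number modestly. With the group removed rather than exchanged, a step of similar or smaller size is expected, direction open, leaning to a slightly higher number. For compound 4 the estimate is 3.5 nM, with a range of 1 nM to 12 nM. The expected step is therefore a 1.6-fold higher number from compound 1 to compound 4 (0.20 log units; within the scatter), at most modest.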

Compound 4, inhibition constant: 0.799 nM
Estimate against measurement, compound 4: 4.4-fold (0.64 log units) above, outside the stated range (below it).
By their numbers in this assay, from the lowest: compounds 3 and 4 (each within the scatter of the next); then compound 1; then compound 2.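

In this assay, taking the methoxy away costs nothing: the change gives a 2.8-fold lower number from compound 1 to compound 4 (0.44 log units; beyond the scatter), so a low number at this position does not depend on a group being present on this aromatic carbon. Exchanging nitro for hydrogen gives a 1.2-fold higher number from compound 3 to compound 4 (0.07 log units; within the scatter), which leaves the two groups indistinguishable here. Going by these compounds alone, the lower number of compound 3 therefore no longer reads as a gain specific to nitro, and methoxy is the one group of the three that stands apart, with the higher number.

Going by these compounds, whether that higher number is peculiar to methoxy stays open, since a hydroxyl, an ethoxy, an amine or a carboxylic acid on the same carbon would test how far it extends. No measurement available here accounts for the difference between methoxy and the other two groups.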